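This account rests on a few compounds, and the source may have more. Where it says the series, first, only, none or still open, it means among the compounds named here.

Working notes on the series, read in a functional assay on a cell-free system (Platelet, plasma, Oryctolagus cuniculus) for inhibition, read by turbidimetry, with a stated time of 5 min; on this read-out lower numbers stand for stronger inhibition and higher numbers for weaker inhibition. Compound 1 (`CCCCC(OC(=O)CN1CCN(CCCCCCOc2ccc(-c3cc(=S)ss3)cc2)CC1)c1ccccc1C(=O)Oc1ccc(/C=C/C(=O)OCCO[N+](=O)[O-])cc1OC`) gives 430000 nM. Compound 2 (`CCCCC(OC(=O)CN1CCN(CCCOc2ccc(-c3cc(=S)ss3)cc2)CC1)c1ccccc1C(=O)Oc1ccc(/C=C/C(=O)OCCCCO[N+](=O)[O-])cc1OC`) gives 430000 nM and compound 3 (`CCCCC(OC(=O)CN1CCN(CCCCOc2ccc(-c3cc(=S)ss3)cc2)CC1)c1ccccc1C(=O)Oc1ccc(/C=C/C(=O)OCCCCO[N+](=O)[O-])cc1OC`) gives 360000 nM. All three numbers lie within the scatter of one another, so compound 1 stands level with the other two and the set offers no ranking.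

Compound 4 (`CCCCC(OC(=O)CN1CCN(CCCCCCOc2ccc(-c3cc(=S)ss3)cc2)CC1)c1ccccc1C(=O)Oc1ccc(/C=C/C(=O)OCCCCO[N+](=O)[O-])cc1OC`) is still unmeasured. It differs from compound 1 in one place, on a saturated chain carbon, two bonds along the chain from an oxygen next to a carbonyl group: 2-(nitrooxy)ethyl in place of nitrooxy on a saturated chain carbon, two bonds along the chain from an oxygen next to a carbonyl group. The same difference reads as 2-(nitrooxy)ethoxy to 4-(nitrooxy)butoxy.

Within the data shown here, no step between measured compounds isolates this change. Still, compound 2 at 430000 nM and compound 3 at 360000 nM carry 4-(nitrooxy)butoxy and sit within the scatter of compound 1, so no step beyond the scatter is expected in either direction. The estimated move is a 1.1-fold lower number from compound 1 to compound 4 (0.04 log units; within the scatter), which stays within the scatter. For compound 4 the estimated value is 390000 nM, with an expected range of 200000 nM to 700000 nM.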

Compound 4, half-maximal inhibitory concentration: 390000 nM
Compound 4: middle estimate and measured number agree at the digits printed; the range from low to high includes it.
By their numbers in this assay, from the lowest: compounds 3, 4, 1 and 2 (each within the scatter of the next).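

In this assay, exchanging 2-(nitrooxy)ethoxy for 4-(nitrooxy)butoxy on a saturated chain carbon, two bonds along the chain from an oxygen next to a carbonyl group, gives a 1.1-fold lower number from compound 1 to compound 4 (0.04 log units; within the scatter). Among these compounds, this pair is the first to isolate the change, and it shows that on the core of compound 1 the two nitrooxy chains cannot be told apart in this read-out. No supporting data bear on this result.

Still open, on these data alone, is whether an amine or a carboxylic acid in place of the nitrooxy group, or a chain longer than 4-(nitrooxy)butoxy, would give a step beyond the scatter at this position. Also open, as far as these compounds go, is whether the same exchange would stay within the scatter on a compound with a much lower number in this assay.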